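Four Stereoisomers of One Scaffold at the Muscarinic M5 Receptor

The source may report more compounds than this note shows. Statements on the series, on what has been measured and on what is new or still open speak of the compounds shown alone.

Measured compounds:
Compound 1 `C[C@@H]1O[C@H]([C@H]2CCCN2C)C[S@@+]1[O-]`: in an assay on CHO cells for binding affinity to muscarinic acetylcholine receptor M5 (Homo sapiens) (on this read-out higher numbers stand for weaker inhibition and lower numbers for stronger inhibition), compound 1 gives < 100000 nM, which is a limit of the assay.
Compound 2 `C[C@H]1O[C@@H]([C@@H]2CCCN2C)C[S@+]1[O-]`: in this assay compound 2 gives < 100000 nM, also a limit.
Compound 3 `C[C@@H]1O[C@H]([C@H]2CCCN2C)C[S@+]1[O-]`: in this assay compound 3 gives < 100000 nM, again a limit.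

Compound 3 therefore stands at the same limit as its two stereoisomers, with no number of its own. Compound 4 `C[C@H]1O[C@@H]([C@H]2CCCN2C)C[S@+]1[O-]` shares every atom and bond with compound 3; (the two compounds have the same atoms and bonds and differ only in configuration as drawn: 2 of 4 stereo elements differ; a stereocentre at a saturated ring carbon is drawn R in compound 3 and S in compound 4; a stereocentre at a saturated ring carbon is drawn R in compound 3 and S in compound 4). The measured steps a step that the two limits leave unreadable from compound 1 to compound 2, a step that the two limits leave unreadable from compound 1 to compound 3 and a step that the two limits leave unreadable from compound 2 to compound 3 cannot be sized, since the limit of < 100000 nM in this assay, at which 3 of the 3 values shown sit, hides any difference between them. A further change of configuration alone, as in the fact that compounds 1 and 3 differ only in the configuration as drawn and (the fact that compounds 2 and 3 differ only in the configuration as drawn), has not yet produced a readable number. Compound 4 is expected to behave like its stereoisomers, so the step that the limit leaves unreadable from compound 3 to compound 4 is estimated as nothing readable. Compound 4 is estimated at 30000 nM, within 3000 nM to 100000 nM, most likely again as a limit.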

Compound 4, inhibition constant: < 100000 nM
Compound 4: no number, only a limit (the forecaster's own chance of this, stated with the estimate: 80%); the middle value does not contradict the limit.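

No step among compound 1, compound 2, compound 3 and compound 4 can be read, because all four sit at the same limit of the assay: the limit of < 100000 nM in this assay, at which 4 of the 4 values shown sit.

The compounds shown leave open whether configuration alone changes the result in this assay at all.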